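The source may report more compounds than this note shows. Statements on the series, on what has been measured and on what is new or still open speak of the compounds shown alone.

Working notes on the amide series sharing the core of compound 1.

Compound 1 `O=C([C@H]1CC2CCC1C2)N1CC(c2nc(-c3cccc(F)c3)no2)C1` gives 72 nM in an assay on HEK293 cells for positive allosteric modulation of metabotropic glutamate receptor 5 (Homo sapiens), read by FLIPR; on this read-out higher numbers stand for an effect only at larger amounts of compound and lower numbers for an effect already at smaller amounts. Compound 2 `CC1CCC(C(=O)N2CC(c3nc(-c4cccc(Cl)c4)no3)C2)CC1` gives 1500 nM in this assay, the highest of the three numbers recorded so far. Compound 3 `O=C(C1CCC(C(F)(F)F)CC1)N1CC(c2nc(-c3cccc(Cl)c3)no2)C1` gives 1000 nM in this assay. Among the compounds with values here, the one single-site step recorded is a 1.5-fold lower number from compound 2 to compound 3 (0.18 log units; within the scatter); the gap between compound 2 and compound 1 lies beyond the scatter, but those two structures differ in more than one place, so no single-site step links them.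

Compound 4 `O=C(c1ccccc1F)N1CC(c2nc(-c3cccc(Cl)c3)no2)C1` is not yet measured. It differs from compound 2 as follows: 2-fluorophenyl in place of 4-methylcyclohexyl on a carbonyl carbon. Within the data shown here, no recorded step bears directly on this change: the only single-site step, trifluoromethyl in place of methyl on a saturated ring carbon, keeps the saturated ring and was within the scatter, while a saturated ring replaced by an aromatic ring on the carbonyl carbon has no precedent among the three measured compounds. The two saturated variants sit close together, and compound 1 shows that another saturated amide can give a far lower number; the direction for an aromatic amide is open. The step is estimated at a 1.9-fold lower number from compound 2 to compound 4 (0.27 log units; within the scatter), with a wide range. Compound 4 is therefore expected to give about 800 nM in this assay, between 150 nM and 4000 nM.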

Compound 4, half-maximal effective concentration: > 10000 nM
Compound 4: only a limit was reported; the forecaster's own chance of this, stated with the estimate: 10%; middle value at least 12-fold (1.09 log units) away from the limit.
By their numbers in this assay, from the lowest: compound 1; then compounds 3 and 2 (each within the scatter of the next). At a limit, above all of these: compound 4.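

Within the data shown here, at the carbonyl carbon, 2-fluorophenyl in place of 4-methylcyclohexyl gives an at least 6.6-fold higher number from compound 2 to compound 4 (0.82 log units; beyond the scatter) in this assay, the first single-site step that lies beyond the scatter. The earlier step, a 1.5-fold lower number from compound 2 to compound 3 (0.18 log units; within the scatter), changed only a group on the saturated ring, whereas this one shows that exchanging the ring itself at this position can matter far more, even though both groups have the same heavy-atom count and neither carries hydrogen-bond donors or acceptors. The reading for compound 4 is a limit and not a number: the limit of > 10000 nM in this assay, at which 1 of the 4 values shown sits.

Still open, going by these compounds, is whether the step follows from the aromatic ring as such or from its fluorine, and an unsubstituted phenyl on the same carbonyl carbon would separate the two. Also open, on these data alone, is how groups of another kind would read at this carbon, such as an open-chain tert-butyl or a ring carrying an amine such as piperidine.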